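Replacing 4-iodophenyl with 3-(methylsulfanyl)propyl

The source may hold more compounds than are shown below. What is called first, only, known or untested is meant among the compounds shown, and "the series" means these compounds.

Among the measured compounds shown here, in an ADME assay on MT4 cells (Homo sapiens) for cytotoxicity (a higher number here means that more compound is tolerated, a lower number that less compound is tolerated), compound 1 (`FC(F)(F)c1cccc(NC(=S)Nc2ccc(I)cc2)c1`) gives 10000 nM as the lower of the two numbers known so far, while compound 2 (`COc1cccc(NC(=S)Nc2cccc(C(F)(F)F)c2)c1`) gives 26000 nM as the higher, a gap beyond the usual scatter. Compound 3 (`CSCCCNC(=S)Nc1cccc(C(F)(F)F)c1`) has 3-(methylsulfanyl)propyl in place of 4-iodophenyl on an amide-type nitrogen. For the measured compounds named here, no measured pair shows such a swap, so any forecast here is loose. A modest rise, beyond the scatter, is expected for this step (a 3.0-fold higher number from compound 1 to compound 3 (0.48 log units; beyond the scatter)). Compound 3 is expected at 30000 nM (range 10000 nM to 90000 nM).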

Compound 3, half-maximal cytotoxic concentration: 43000 nM
Compound 3: the middle estimate sits 1.4-fold (0.16 log units) below what was measured; the range from low to high includes it.
By their numbers in this assay, from the lowest: compound 1; then compounds 2 and 3 (each within the scatter of the next).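

In this assay the place on the amide-type nitrogen turns out not to need an aromatic ring: 3-(methylsulfanyl)propyl in place of 4-iodophenyl gives a clear change (a 4.3-fold higher number from compound 1 to compound 3 (0.63 log units; beyond the scatter)). A flexible chain with no ring is therefore tolerated here at least as well as the 4-iodophenyl group. Nothing available explains this rise. On these data alone, it remains open whether the sulfur or the ring's removal matters more. A plain butyl chain, or a chain ending in an amine, would help to separate the two.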